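A few compounds are considered here, and "the series" means these few. Any claim that something is new, unique, unknown or untested is made for them only; others in the source may bear on it.

Measured so far in an assay on LM cells for displacement of a labelled ligand from Neuropeptide Y receptor type 5 (Homo sapiens); on this read-out higher numbers stand for weaker inhibition and lower numbers for stronger inhibition:
Compound 1 `Fc1ccc(C2(c3ccc(F)cc3)CNC(c3ccccc3)=N2)cc1` gives 32 nM in this assay.
Compound 2 `O=[N+]([O-])c1cccc(C2=NC(c3ccc(F)cc3)(c3ccc(F)cc3)CN2)c1` gives 4.3 nM in this assay.
Compound 3 `N#Cc1cccc(C2=NC(c3ccc(F)cc3)(c3ccc(F)cc3)CN2)c1` gives 2.7 nM in this assay.

Compound 3 holds the lowest number of the three. Its separation from compound 1 is clear, a 12-fold lower number from compound 1 to compound 3 (1.07 log units; beyond the scatter), while the gap to compound 2, a 1.6-fold lower number from compound 2 to compound 3 (0.20 log units; within the scatter), stays within the scatter, so compounds 2 and 3 are not ranked against each other.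

Compound 4 `CC(=O)c1cccc(C2=NC(c3ccc(F)cc3)(c3ccc(F)cc3)CN2)c1` is not yet measured. The change is acetyl in place of cyano on an aromatic carbon. For the measured compounds named here, two measured steps bear on it: putting a group on that ring carbon lowered the number in both cases, a 7.4-fold lower number from compound 1 to compound 2 (0.87 log units; beyond the scatter) and a 12-fold lower number from compound 1 to compound 3 (1.07 log units; beyond the scatter), and exchanging one such group for another, a 1.6-fold lower number from compound 2 to compound 3 (0.20 log units; within the scatter), moved the number only within the scatter. Going by the values given here, no measured step covers acetyl itself, so the comparison rests on the nitro and cyano cases only.

The expected step is small, a 1.9-fold higher number from compound 3 to compound 4 (0.27 log units; within the scatter), most likely within the scatter, with a slight lean toward a higher number. Compound 4 is estimated at 5 nM, in the range 1.5 nM to 20 nM.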

Compound 4, half-maximal inhibitory concentration: 44 nM
Compound 4: middle estimate off by 8.8-fold (0.94 log units), on the low side; the measured number lies above the stated range.
By their numbers in this assay, from the lowest: compounds 3 and 2 (each within the scatter of the next); then compounds 1 and 4 (each within the scatter of the next).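

In this assay, the gain seen with nitro and cyano on this aromatic carbon does not extend to every group placed there: acetyl gives it up, with a 16-fold higher number from compound 3 to compound 4 (1.21 log units; beyond the scatter) and a 10-fold higher number from compound 2 to compound 4 (1.01 log units; beyond the scatter), while a 1.4-fold higher number from compound 1 to compound 4 (0.14 log units; within the scatter) leaves acetyl not separated from hydrogen. The position is therefore not merely improved by any group, since the exchange of nitro for cyano stayed within the scatter but the exchange of either for acetyl did not, and the matching hydrogen-bond acceptor counts of cyano and acetyl do not separate those two. The data at hand offer no explanation for this difference.

From the compounds shown here alone, whether the loss belongs to acetyl alone or to a wider set of groups stays open. A primary amide, a methyl ester, a chlorine or a methyl group on the same aromatic carbon would help to settle this.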